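A few compounds are considered here, and "the series" means these few. Any claim that something is new, unique, unknown or untested is made for them only; others in the source may bear on it.

Measured so far:
compound 1 `Cc1ccc(-c2ccccc2NCC2=NCCN2)o1`: 2.69 nM
compound 2 `c1ccc(-c2cnccn2)c(NCC2=NCCN2)c1`: 4.57 nM

In a functional assay for activation of Alpha-1A adrenergic receptor (Homo sapiens), read by calcium flux (a lower number here means that less compound is needed, a higher number that more compound is needed for the effect), compound 1 gives 2.69 nM, and compound 2 gives 4.57 nM. For the measured compounds named here, the one step measured, a 1.7-fold higher number from compound 1 to compound 2 (0.23 log units; within the scatter), swaps one aromatic group for another. Compound 2 has the highest of the two numbers, yet sits within the scatter of compound 1. Compound 3 `CO/N=C(\C)c1ccccc1NCC1=NCCN1` differs from compound 2 by a group of 5 heavy atoms (3 carbon, 1 nitrogen, 1 oxygen; no ring) in place of a group of 6 heavy atoms (4 carbon, 2 nitrogen; one six-membered aromatic ring with 2 hetero atoms), on an aromatic carbon. The measured step bears only loosely on this change, since here a group with no ring enters. With no step beyond the scatter in hand, compound 3 is expected to stay close to compound 2, a 1.3-fold higher number from compound 2 to compound 3 (0.12 log units; within the scatter). Compound 3 is therefore estimated at 6 nM, expected between 1.5 nM and 25 nM.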

Compound 3, half-maximal effective concentration: 20.9 nM
For compound 3 the middle estimate is 3.5-fold (0.54 log units) below the measured one, within the range that was stated.
By their numbers in this assay, from the lowest: compounds 1 and 2 (each within the scatter of the next); then compound 3.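

Of the changes shown at this position, only replacing an aromatic ring with a group that has no ring moves the number beyond the scatter (a 4.6-fold higher number from compound 2 to compound 3 (0.66 log units; beyond the scatter)). The same holds against the 5-methylfuran-2-yl group of compound 1 (a 7.8-fold higher number from compound 1 to compound 3 (0.89 log units; beyond the scatter)), so both ring-bearing groups need less compound than the open group of compound 3. Nothing available explains why the number rises with this change. The compounds shown leave open whether the loss of a ring matters or only this particular group. A phenyl ring, an amine or a simple ethyl chain at the same place would help separate the two.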